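Series notes: the step from compound 3 to compound 4

A few compounds are considered here, and "the series" means these few. Any claim that something is new, unique, unknown or untested is made for them only; others in the source may bear on it.

Measured in an assay on isolated protein for inhibition of Amine oxidase [flavin-containing] B (Homo sapiens), read by fluorescence, with stated times of 15 min and 20 min; on this read-out higher numbers stand for weaker inhibition and lower numbers for stronger inhibition:
- compound 1 `CC(C)(C)c1cc(C(=O)NC2CCN(Cc3ccccc3)CC2)cc(C(C)(C)C)c1O` gives 85100 nM
- compound 2 `CC(C)(C)c1cc(CCC(=O)NC2CCN(Cc3ccccc3)CC2)cc(C(C)(C)C)c1O` gives 70400 nM
- compound 3 `Cc1ccccc1CN1CCC(CCNC(=O)/C=C/c2cc(C(C)(C)C)c(O)c(C(C)(C)C)c2)CC1` gives 7200 nM

Compound 3 holds the lowest number of the three, and its distance from compound 2 as well as from compound 1 lies beyond the scatter of repeats in this assay, so on these numbers it is the strongest inhibitor of the set. Compound 1 and compound 2 lie within the scatter of each other, and no order is drawn between them.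

Compound 4 `CC(C)(C)c1cc(/C=C/C(=O)NCCC2CCN(Cc3cccc([N+](=O)[O-])c3)CC2)cc(C(C)(C)C)c1O` is not yet measured. It differs from compound 3 in one place: 3-nitrophenyl in place of 2-methylphenyl on a saturated chain carbon bound to an amine nitrogen in a ring. Going by the values given here, no pair of measured compounds carries this change, so its effect in this assay has no precedent here; the three measured compounds differ from one another elsewhere in the structure, and all three carry the same kind of group on the saturated chain carbon bound to the amine nitrogen in the ring. The working expectation is therefore a step of modest size from compound 3 to compound 4, a 1.4-fold higher number from compound 3 to compound 4 (0.14 log units; within the scatter), with the direction left open and a result within the scatter not excluded. For compound 4 the number in this assay is estimated at 10000 nM, with a range from 2500 nM to 40000 nM.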

Compound 4, half-maximal inhibitory concentration: 12500 nM
The estimate for compound 4 lay 1.3-fold (0.10 log units) below the measured number, and the stated range covers the measured number.
By their numbers in this assay, from the lowest: compounds 3 and 4 (each within the scatter of the next); then compounds 2 and 1 (each within the scatter of the next).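

In this assay, going by these compounds alone, 3-nitrophenyl in place of 2-methylphenyl on a saturated chain carbon bound to an amine nitrogen in a ring gives a 1.7-fold higher number from compound 3 to compound 4 (0.24 log units; within the scatter), the first reading of a change at this place, since no earlier pair of compounds differed there. The swap from 2-methylbenzyl to 3-nitrobenzyl takes the group from 7 to 9 heavy atoms and from 0 to 2 hydrogen-bond acceptors, yet the two compounds cannot be told apart on this read-out, so this place accepts at least this one exchange without a separable change in the number. No supporting data bear on why the exchange leaves the reading within the scatter.

One pair changes both the group and its numbered place on the ring together, so 2-nitrobenzyl and 3-methylbenzyl would be needed to separate the two. From the compounds shown here alone, whether this place stays as permissive for a different kind of group, such as an amine or a carboxylic acid on the phenyl ring, remains open.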